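This account rests on a few compounds, and the source may have more. Where it says the series, first, only, none or still open, it means among the compounds named here.

Working notes on the series in an ADME assay on microsomes (Homo sapiens) for metabolic stability; on this read-out higher numbers stand for a longer-lived compound and lower numbers for a shorter-lived compound.

Compound 1 `CC(C)(C)C(=O)N1N=CCC1c1cocn1` carries a tert-butyl on the carbonyl carbon. Compound 2 `O=C(c1cscn1)N1CCC(C(=O)N2N=CC[C@H]2c2ccccc2)CC1` and compound 3 `O=C(C1CCOCC1)N1N=CCC1c1ccccc1` share the same core as compound 1 but with a phenyl on the ring. In this assay compound 1 gives > 1.5 h, a limit of the assay rather than a number. Compound 2 gives > 3 h in this assay, again a limit rather than a number. Compound 3 gives > 1.5 h in this assay, which is also a limit and not a number. Compound 3 thus sits at the limit of > 1.5 h in this assay, at which 2 of the 3 values shown sit, while the other value shown sits at the limit of > 3 h in this assay, at which 1 of the 3 values shown sits; with every value a limit, no ordering among the three can be read.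

Compound 4 `CC(C)C(=O)N1N=CCC1c1ccccc1` differs from compound 3 in one place: isopropyl in place of oxan-4-yl on a carbonyl carbon. Among the measured compounds shown here, no measured step in this assay covers this kind of change, so the step is expected to be none beyond the scatter, with the estimate for compound 4 in this assay as 2 h between 0.8 h and 5 h. The expected step from compound 3 to compound 4 is a step that the limit leaves unreadable from compound 3 to compound 4, and a limit rather than a number is expected, since compound 3 gives > 1.5 h and compound 1 gives > 1.5 h.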

Compound 4, half-life: > 1.5 h
Compound 4: only a limit was reported (the forecaster's own chance of this, stated with the estimate: 60%); the middle value is on the limit's open side.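

Compound 3 and compound 4 both stand as limits rather than numbers in this assay, and no step can be read between them. The compounds shown leave open how isopropyl and oxan-4-yl on a carbonyl carbon compare in half-life.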